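The compounds below may be only part of what the source reports. "The series", "measured", "known", "first", "only" and "open" are said of these compounds alone.

Measured so far:
Compound 1, `CCCCc1ccc2[nH]c(-c3ccccc3)c(C3=C(Br)C(=O)NC3=O)c2c1`, gives 3.74 in a physicochemical assay for lipophilicity; on this read-out lower numbers stand for lower lipophilicity and higher numbers for higher lipophilicity.
Compound 2, `CCCCCc1ccc2[nH]c(-c3ccccc3)c(C3=C(Br)C(=O)NC3=O)c2c1`, gives 4.07 in this assay.
Compound 3, `COc1ccc(-c2[nH]c3ccc(C)cc3c2C2=C(Br)C(=O)NC2=O)cc1`, gives 2.85 in this assay.

Compound 1 and compound 2 differ in one place: methyl in place of hydrogen on a saturated chain carbon, four bonds along the chain from an aromatic carbon. That change made a step of a number 0.33 log units higher from compound 1 to compound 2 (beyond the scatter). Compound 3 stands lowest of the three; the difference between its core and the core of compound 1 is not broken down here, and their values simply show compound 3 well below compound 1.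

Compound 4, `CCc1ccc2[nH]c(-c3ccc(OC)cc3)c(C3=C(Br)C(=O)NC3=O)c2c1`, is not yet measured. It differs from compound 3 in one place: methyl in place of hydrogen on a saturated chain carbon bound to an aromatic carbon. Within the data shown here, this is the same kind of change as the one from compound 1 to compound 2, but the place is not the same: there the methyl entered four bonds along the chain from an aromatic carbon, here it enters on a saturated chain carbon bound to an aromatic carbon.

Among the measured compounds shown here, a step of a number 0.40 log units higher from compound 3 to compound 4 (beyond the scatter) is expected, because a number 0.33 log units higher from compound 1 to compound 2 (beyond the scatter) was the only comparable step seen. In this assay compound 4 is therefore estimated at 3.25, most likely between 2.95 and 3.55.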

Compound 4, partition coefficient: 3.23
Beside the measured number, compound 4's estimate is 0.02 log units above it; measured number inside the range.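

In this assay methyl in place of hydrogen gave a number 0.38 log units higher from compound 3 to compound 4 (beyond the scatter) on one core, while on a different core the same kind of change gave a number 0.33 log units higher from compound 1 to compound 2 (beyond the scatter) at a different place on the chain. Both steps go in the same direction and both are modest and beyond the scatter, so in these two pairs the change carried over from one core to the other; two pairs, however, make no rule for the series, and since the place differs along with the core, they cannot show how much either one matters. Nothing available here explains why the number rises with this change.

The compounds shown leave open whether a longer chain, such as propyl, would keep raising the number on the core of compound 3. They also leave open what an amine or a carboxylic acid on that chain would do to the reading.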